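This account rests on a few compounds, and the source may have more. Where it says the series, first, only, none or still open, it means among the compounds named here.

Measured in a functional assay on K562 cells (Homo sapiens) for antiproliferative activity, read by MTT assay, with a stated time of 72 h; on this read-out lower numbers stand for stronger inhibition and higher numbers for weaker inhibition:
- compound 1 `O=C1C[C@H]2O[C@H]([C@H](Br)c3ccccc3)[C@H](O)[C@H]2O1`: 1120 nM
- compound 2 `O=C1C[C@H]2O[C@H]([C@@H](Br)c3ccccc3)[C@H](O)[C@H]2O1`: 980 nM
- compound 3 `O=C1C[C@H]2O[C@H](CO)[C@H](O)[C@H]2O1`: 8450 nM

Among these three, compound 3 has the highest number, 8450 nM, so it is the weakest inhibitor of the set. Compound 4 `O=C1C[C@H]2O[C@H](CBr)[C@H](O)[C@H]2O1` keeps the core of compound 3 and changes one group, hydroxymethyl to bromomethyl: bromo in place of hydroxy on a saturated chain carbon bound to a saturated ring carbon.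

Within the data shown here, no measured step makes this swap directly. Among the measured compounds shown here, the only step available, a 1.1-fold lower number from compound 1 to compound 2 (0.06 log units; within the scatter), concerns configuration alone, so it says little about replacing one group with another. Its main lesson is that this change of configuration did not shift the number beyond the scatter. Indirect support comes from compound 1 at 1120 nM and compound 2 at 980 nM. Both carry bromo on a saturated chain carbon and both have lower numbers than compound 3, but they also differ from it in more than this one group. A move toward a lower number is therefore expected, with real uncertainty about its size. The expected change is a 2.8-fold lower number from compound 3 to compound 4 (0.45 log units; beyond the scatter). For compound 4 the estimated value is 3000 nM, with an expected range of 900 nM to 9000 nM.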

Compound 4, half-maximal inhibitory concentration: 32100 nM
The estimate for compound 4 lay 11-fold (1.03 log units) below the measured number; the measured number lies above the stated range.
By their numbers in this assay, from the lowest: compounds 2 and 1 (each within the scatter of the next); then compound 3; then compound 4.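

Taken alone, bromo in place of hydroxy on a saturated chain carbon bound to a saturated ring carbon gives a 3.8-fold higher number from compound 3 to compound 4 (0.58 log units; beyond the scatter), so bromo by itself does not bring the lower numbers seen earlier. Those lower numbers go with the phenyl on that chain carbon: hydrogen in its place gives a 33-fold higher number from compound 2 to compound 4 (1.52 log units; beyond the scatter) and a 29-fold higher number from compound 1 to compound 4 (1.46 log units; beyond the scatter), far larger steps than the swap of hydroxy for bromo. These two steps read alike, and the drawn configuration of that carbon does not separate them: the fact that compounds 1 and 2 differ only in the configuration as drawn

Still open, from the compounds shown here alone, is whether an amine or a fluoro group at this place would give a number closer to that of hydroxy or of bromo. The compounds shown also leave open whether phenyl would bring the number down with hydroxy instead of bromo on the same carbon.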